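Changing the nitrogen substituent: compound 2 to compound 3

A few compounds are considered here, and "the series" means these few. Any claim that something is new, unique, unknown or untested is made for them only; others in the source may bear on it.

In a functional assay on K562 cells (Homo sapiens) for cytotoxicity, read by MTT assay, with a stated time of 3 days (on this read-out lower numbers stand for stronger inhibition and higher numbers for weaker inhibition), two compounds of the series have been measured. Among the compounds with values here, compound 1 (`N#Cc1c(Nc2ccccc2)nc(SCc2nc3ccccc3[nH]2)nc1-c1ccccc1`) gives 3.2 nM, and compound 2 (`CCNc1nc(SCc2nc3ccccc3[nH]2)nc(-c2ccccc2)c1C#N`) gives 4.38 nM, so compound 2 stands within the scatter of the only other number available. The next compound is compound 3 (`N#Cc1c(NC(N)=S)nc(SCc2nc3ccccc3[nH]2)nc1-c1ccccc1`), not yet measured in this assay. Its change from compound 2 is a group of 3 heavy atoms (1 carbon, 1 nitrogen, 1 sulfur; no ring) in place of a group of 2 heavy atoms (2 carbon; no ring), on a nitrogen on an aromatic ring, a group of 3 heavy atoms in place of ethyl, on a nitrogen on an aromatic ring.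

Within the data shown here, one measured step bears on this change: a 1.4-fold higher number from compound 1 to compound 2 (0.14 log units; within the scatter), where ethyl replaces phenyl on that nitrogen. That single step shows tolerance for two different groups only. Among the measured compounds shown here, no measured compound carries the entering group, so the range has to stay wide. Based on that step, a 1.1-fold higher number from compound 2 to compound 3 (0.06 log units; within the scatter) is the estimated step, and no shift beyond the scatter is expected. For compound 3 the estimated value is 5 nM, with an expected range from 1.5 nM to 20 nM.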

Compound 3, half-maximal inhibitory concentration: 11.9 nM
Compound 3: middle estimate off by 2.4-fold (0.38 log units), on the low side; the range from low to high includes it.
By their numbers in this assay, from the lowest: compounds 1 and 2 (each within the scatter of the next); then compound 3.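

In this assay the nitrogen on an aromatic ring proves not to be indifferent to its substituent: the group of 3 heavy atoms (1 carbon, 1 nitrogen, 1 sulfur) brings a 2.7-fold higher number from compound 2 to compound 3 (0.43 log units; beyond the scatter) and a 3.7-fold higher number from compound 1 to compound 3 (0.57 log units; beyond the scatter) with both steps beyond the scatter. Ethyl and phenyl had stayed within the scatter of each other, so this is the first group at this position to separate from the others, and the shift runs toward weaker inhibition, though compound 3 still gives 11.9 nM and the step stays modest. No measurement at hand accounts for the shift.

Within the data shown here, with only three groups on this nitrogen, it stays open whether the higher number belongs to the sulfur or to the entering group as a whole, which a urea with oxygen in place of the sulfur would help to separate. On these data alone, it is equally open how an acetyl group, the free amine or a longer chain such as butyl on the same nitrogen would compare with ethyl and phenyl.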